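The source may report more compounds than this note shows. Statements on the series, on what has been measured and on what is new or still open speak of the compounds shown alone.

Measured compounds:
compound 1 `O=C(Nc1cccc(-n2cc(-c3ccncc3)c(-c3cc(O)cc(Cl)c3)n2)c1)Nc1ccc(Cl)c(C(F)(F)F)c1`, 101%
compound 2 `O=C(Nc1cccc(-n2cc(-c3ccncc3)c(-c3cc(O)cc(Cl)c3)n2)c1)Nc1ccc(Cl)c(Cl)c1`, 88%
compound 3 `COc1cc(Cl)cc(-c2nn(-c3cccc(NC(=O)Nc4cc(C(F)(F)F)cc(C(F)(F)F)c4)c3)cc2-c2ccncc2)c1`, 95%

In a functional assay on NCI-H322M cells (Homo sapiens) for inhibition, read by sulforhodamine B assay, with a stated time of 48 h, tested at 0.1 uM (on this read-out higher numbers stand for a weaker effect at the one concentration tested and lower numbers for a stronger effect), compound 2 gives the lowest of the three numbers. Its nearest neighbour is compound 3 at 95%, a gap that stays within the scatter, so no order can be read between these two. Among the measured compounds shown here, compound 1 lies furthest off, and the one measured step, a number 13 percentage points lower from compound 1 to compound 2 (beyond the scatter), covers that pair.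

Compound 4 `COc1cc(Cl)cc(-c2nn(-c3cccc(NC(=O)Nc4ccc(Cl)c(Cl)c4)c3)cc2-c2ccncc2)c1` has not yet been measured in this assay. It differs from compound 2 in one place: methyl in place of hydrogen on an oxygen on an aromatic ring. For the measured compounds named here, none of the measured steps bears on this change. Going by the values given here, the only step in the set concerns the chloro and trifluoromethyl groups on the other aryl ring of the urea, and compound 3, the one compound that carries a methoxy group, differs from compound 2 in two places at once, so its value cannot be split between the two changes. Among the compounds with values here, with no step to lean on, the expectation for compound 4 is a step of a number 3 percentage points higher from compound 2 to compound 4 (within the scatter), which is not beyond the scatter. Compound 4 is therefore estimated at 91% in this assay, with a range from 78% to 104%.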

Compound 4, a percentage reported as activity, at one concentration (the size of the read-out at that concentration, not a potency): 90%
For compound 4 the middle estimate is 1 percentage points above the measured one, within the range that was stated.
By their numbers in this assay, from the lowest: compounds 2, 4, 3 and 1 (each within the scatter of the next, the first and the last beyond it).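

In this assay, the change from hydroxy to methoxy on the 3-chloro-5-hydroxyphenyl group gives a step of a number 2 percentage points higher from compound 2 to compound 4 (within the scatter) with the rest of compound 2 left as it stands, so this pair shows no readable effect of placing a methyl on this oxygen at the one concentration tested. The earlier compounds shown here could not show this, since compound 3 carries its methoxy only together with a second difference on the other aryl ring of the urea, whereas this single change isolates the oxygen and indicates that the hydrogen on it is not required to hold the read-out at this level. Nothing in the data gives a reason for this outcome.

As far as these compounds go, whether a longer chain on this oxygen, such as ethoxy or benzyloxy, or an amine or a carboxylic acid in place of the hydroxy group would leave the read-out equally unmoved remains open. Also open, from the compounds shown here alone, is whether the same lack of a step would hold with a trifluoromethyl group on the other aryl ring of the urea, or at a concentration other than the single one tested here.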